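From Bromo to Iodo on the Aryl Ring

The source may report more compounds than this note shows. Statements on the series, on what has been measured and on what is new or still open speak of the compounds shown alone.

Two compounds of this series carry numbers. Compound 1 `Nc1scc(-c2ccc(F)cc2)c1C(=O)c1ccccc1` was tested in a functional assay on CHO cells for agonist activity at adenosine receptor A1 (Homo sapiens), read by fluorescence and ERK phosphorylation, with stated times of 30 min and 1.5 h, tested at 3 uM (a higher number here means a stronger effect of the compound at the concentration tested, a lower number a weaker effect), and gives 51%. Compound 2 `Nc1scc(-c2ccc(Br)cc2)c1C(=O)c1ccccc1` gives 46% in this assay. Going by the values given here, the single step between them, a number 5 percentage points lower from compound 1 to compound 2 (within the scatter), is bromo in place of fluoro on an aromatic carbon. Compound 2 thus holds the lowest of the two numbers, yet its nearest neighbour, compound 1, lies within the scatter, so the two are not told apart.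

Compound 3 `Nc1scc(-c2ccc(I)cc2)c1C(=O)c1ccccc1` has not yet been measured. It differs from compound 2 as follows: iodo in place of bromo on an aromatic carbon. Among the compounds with values here, the only measured step that bears on this change is the earlier halogen exchange at the same carbon, a number 5 percentage points lower from compound 1 to compound 2 (within the scatter), which stayed within the scatter. A further halogen exchange at that place is therefore expected to move this assay little, if at all. The step this estimate means is expected to be a number 2 percentage points lower from compound 2 to compound 3 (within the scatter), not beyond the scatter. Compound 3 is estimated to give 44% in this assay, with a range from 30% to 58%.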

Compound 3, a percentage reported as activity, at one concentration (the size of the read-out at that concentration, not a potency): 51%
Compound 3: middle estimate off by 7 percentage points, on the low side; low and high end bracket the measured number.
By their numbers in this assay, from the lowest: compounds 2, 1 and 3 (each within the scatter of the next).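

With iodo in place of bromo on an aromatic carbon, para to a large group, this assay shows a number 5 percentage points higher from compound 2 to compound 3 (within the scatter), so this second exchange at the same carbon also leaves the two compounds untold apart. Set against the first halogen in the series, the step with iodo in place of fluoro is no change at the digits printed from compound 1 to compound 3 (within the scatter), which means that fluoro, bromo and iodo at this one place now form a set of three compounds whose numbers all lie within the scatter of the next, where the earlier pair offered only a single comparison. Nothing available for these compounds gives a reason why the read-out holds across the three halogens.

On these data alone, all three changes stay among halogens, so whether this carbon would hold the read-out with an amine, a carboxylic acid, a methoxy group or a longer chain in their place remains open. As far as these compounds go, the read-out also gives the size of the effect at one concentration only, so whether compounds with such similar numbers would also show a similar effect at other concentrations remains open as well.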